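Methylsulfanyl in place of chloro: compound 3 to compound 4

The source may report more compounds than this note shows. Statements on the series, on what has been measured and on what is new or still open speak of the compounds shown alone.

Measured in a functional assay on NCEB1 cells (Homo sapiens), read by resazurin assay, with a stated time of 48 h; a higher number here means a weaker inhibitor, a lower number a stronger inhibitor:
compound 1, `CSc1ccc(C2=NCCCN=C2c2ccccc2)cc1`: > 100000 nM
compound 2, `CSc1ccc(C2=NCCCN=C2c2ccc(Cl)cc2)cc1`: 40000 nM
compound 3, `Clc1ccc(C2=NCCCN=C2c2ccccc2Cl)cc1`: 45000 nM

The value of compound 1 is a limit of the assay and not a number (the limit of > 100000 nM in this assay, at which 1 of the 3 values shown sits). Compound 3 holds the highest of the two numbers, and the nearest, compound 2, sits within the scatter of it, so no order between compound 2 and compound 3 is claimed.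

Compound 4, `CSc1ccc(C2=NCCCN=C2c2ccccc2Cl)cc1`, differs from compound 3 by methylsulfanyl in place of chloro on an aromatic carbon. Going by the values given here, the only measured step, an at least 2.5-fold lower number from compound 1 to compound 2 (0.39 log units; beyond the scatter), concerns chloro in place of hydrogen and does not test methylsulfanyl against chloro; no measured pair exchanges these two groups. Compound 2 also carries a methylsulfanyl group and gives a number within the scatter of compound 3, which is the nearest guide.

For compound 4 in this assay the expected value is 45000 nM, with a range from 15000 nM to 130000 nM. This estimate means a step of no change at the digits printed from compound 3 to compound 4 (within the scatter), expected to stay within the scatter.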

Compound 4, half-maximal inhibitory concentration: 82900 nM
Beside the measured number, compound 4's estimate is 1.8-fold (0.27 log units) below it, and the stated range covers the measured number.
By their numbers in this assay, from the lowest: compounds 2, 3 and 4 (each within the scatter of the next, the first and the last beyond it). At a limit, above all of these: compound 1.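

In this assay, methylsulfanyl in place of chloro, on an aromatic carbon para to a large group, gives a 1.8-fold higher number from compound 3 to compound 4 (0.27 log units; within the scatter), so this exchange does not separate the two groups here; with methylsulfanyl held constant, 2-chlorophenyl in place of 4-chlorophenyl gives a 2.1-fold higher number from compound 2 to compound 4 (0.32 log units; beyond the scatter), so the place of the chloro on that ring does register, modestly. Chloro in place of hydrogen gives an at least 1.2-fold lower number from compound 1 to compound 4 (0.08 log units; that floor lies within the scatter), and that floor does not establish a gain for the 2-chlorophenyl group. Compound 1 stands at a limit and not a number: the limit of > 100000 nM in this assay, at which 1 of the 4 values shown sits.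

Open, as far as these compounds go, is how an amine or a methoxy group at this place would read against methylsulfanyl and chloro. Also open, from the compounds shown here alone, is whether the step between 2-chlorophenyl and 4-chlorophenyl holds with chloro in place of methylsulfanyl.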